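This account rests on a few compounds, and the source may have more. Where it says the series, first, only, none or still open, it means among the compounds named here.

Working notes on the series, following the step from compound 1 to compound 4.

Compound 1 `CCCC[C@H](CC)C[C@]1(CC)C=C(CC)/C(=C/C(=O)OC)O1` is the anchor of the set. For the measured compounds named here, in a functional assay on K562 cells (Homo sapiens) for cytotoxicity, read by MTT assay, with a stated time of 72 h (a higher number here means a weaker inhibitor, a lower number a stronger inhibitor), compound 1 gives 5300 nM, the lowest of the two numbers measured so far. Compound 3 `CCCCC(CC)CC(O)(/C=C(/CC)[C@@H](O)CC(=O)OC)CC` gives 20000 nM in this assay, a gap to compound 1 that lies beyond the scatter. Compound 2 `CCCCC(C)C[C@]1(CC)O[C@H]1[C@]1(CC)C=CC(=O)O1` reaches only a limit of the assay, > 50000 nM, which is the limit of > 50000 nM in this assay, at which 1 of the 3 values shown sits. Going by the values given here, no two measured compounds differ in a single place, so no measured step is available to lean on.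

Compound 4 `CC/C=C/[C@H](CC)C[C@]1(CC)C=C(CC)/C(=C/C(=O)OC)O1` is not yet measured in this assay. Its difference from compound 1 is but-1-en-1-yl in place of butyl on a saturated chain carbon bound to two saturated chain carbons. The change keeps the chain length and adds a single double bond far from the core, with no new donors or acceptors. The step from compound 1 to compound 4 is expected to be small, in either direction, and not beyond the scatter: the estimated change is a 1.0-fold higher number from compound 1 to compound 4 (0.02 log units; within the scatter). Compound 4 is therefore expected at about 5500 nM, with a range of 2200 nM to 14000 nM.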

Compound 4, half-maximal inhibitory concentration: 800 nM
Compound 4: the middle estimate sits 6.9-fold (0.84 log units) above what was measured; the measured number lies below the stated range.
By their numbers in this assay, from the lowest: compound 4; then compound 1; then compound 3. At a limit, above all of these: compound 2.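

For the compounds shown here, the chain on this saturated chain carbon bound to two saturated chain carbons turns out to matter, which the earlier compounds, none differing in a single place, could not show. In this assay but-1-en-1-yl in place of butyl gives a 6.6-fold lower number from compound 1 to compound 4 (0.82 log units; beyond the scatter) and leaves compound 4 with the lowest number shown. The heavy-atom count stays the same and no hydrogen-bond donor or acceptor enters, so the two chains differ only by one double bond outside aromatic rings. Nothing in the evidence at hand bears on this result.

Open, from the compounds shown here alone, is whether a double bond is specifically required here, or whether a triple bond, a longer chain or a terminal hydroxyl would serve as well. Also open, going by these compounds, is whether the same change would carry over to the differing cores of compound 2 and compound 3.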